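A few compounds are considered here, and "the series" means these few. Any claim that something is new, unique, unknown or untested is made for them only; others in the source may bear on it.

Compounds measured in a functional assay on SW1573 cells (Homo sapiens) for inhibition, read by sulforhodamine B assay, with a stated time of 48 h; on this read-out higher numbers stand for weaker inhibition of growth and lower numbers for stronger inhibition of growth:
- compound 1 `CC(=O)OC/C(=C\c1ccc(Cl)cc1)C(=O)c1ccc(Cl)cc1`: 3400 nM
- compound 2 `C=C(C/C(=C\c1ccc(Cl)cc1)C(=O)c1ccccc1)C(=O)c1ccccc1`: 6100 nM

Compound 2 `C=C(C/C(=C\c1ccc(Cl)cc1)C(=O)c1ccccc1)C(=O)c1ccccc1` stands with the highest of the two numbers in this assay, but its nearest neighbour is compound 1, whose value in this assay is 3400 nM, and that gap lies within the usual scatter of the measurement, so the two compounds cannot be told apart on these numbers.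

The step under consideration leads from compound 2 to compound 3 `C=C(C/C(=C\c1ccccc1F)C(=O)c1ccccc1)C(=O)c1ccccc1`. Going by the values given here, its single change is 2-fluorophenyl in place of 4-chlorophenyl on a double-bonded chain carbon bound to a double-bonded chain carbon. Among the compounds with values here, no measured pair in this set shows this change, and nothing else among the measured compounds speaks to the exchange of a 4-chlorophenyl for a 2-fluorophenyl on the double-bonded chain carbon bound to a double-bonded chain carbon. Within the data shown here, with no comparable step available, the expected step of a 1.0-fold lower number from compound 2 to compound 3 (0.01 log units; within the scatter) is taken to be none beyond the scatter, in neither direction. On that basis compound 3 is estimated at 6000 nM in this assay, with a range from 2500 nM to 15000 nM.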

Compound 3, concentration for 50% growth inhibition: 3500 nM
Beside the measured number, compound 3's estimate is 1.7-fold (0.23 log units) above it; the measured number falls inside the stated range.
By their numbers in this assay, from the lowest: compounds 1, 3 and 2 (each within the scatter of the next).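

Going by these compounds alone, this step gives the first reading of any change at this place on the shared core: in this assay, putting 2-fluorophenyl in place of 4-chlorophenyl on a double-bonded chain carbon bound to a double-bonded chain carbon gives a 1.7-fold lower number from compound 2 to compound 3 (0.24 log units; within the scatter) and so leaves the growth-inhibition read-out unchanged within the usual scatter. The exchange alters both the halogen and the number in the group's name, and this single step shows only that the two alterations taken together produce no distinguishable difference, without showing how each one acts alone. No measurement bears on why the read-out stays within the scatter for this exchange.

The compounds shown leave open whether 4-fluorophenyl, 2-chlorophenyl or an unsubstituted phenyl would also stay within the scatter, and whether a ring carrying a methoxy group, a dimethylamino group or a carboxylic acid would move the number beyond it. They also leave open whether the same exchange would behave alike on the core of compound 1, which carries 4-chlorophenyl at the corresponding place.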